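This account rests on a few compounds, and the source may have more. Where it says the series, first, only, none or still open, it means among the compounds named here.

Of the compounds shown here, three of one shared core have been measured in an ADME assay (liver) for metabolic stability, with Liver microsome (Homo sapiens) as the target, read by LC-MS, using microsomes, with a stated time of 1 h, tested at 5 uM; on this read-out lower numbers stand for a less stable compound and higher numbers for a more stable compound. Compound 1 `Cc1nc(-c2ccccc2)c(C(=O)N2CCN(c3cccc(C#N)c3)CC2)o1` gives 8%, compound 2 `Cc1nc(-c2ccccc2)c(C(=O)N2CCN(c3cccc(C)c3C)CC2)o1` gives 29.8%, and compound 3 `Cc1nc(-c2cccc(F)c2)c(C(=O)N2CCN(c3cc(Cl)cc(Cl)c3)CC2)o1` gives 75.9%. Among these three numbers compound 2 stands second highest: compound 1 sits a number 21.8 percentage points higher from compound 1 to compound 2 (beyond the scatter), a step beyond the scatter, and compound 3 lies further away on the other side. For the measured compounds named here, compound 3 also differs from compound 2 in more than one place, so no single step is given for that pair.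

Compound 4 `Cc1cc(C)cc(N2CCN(C(=O)c3oc(C)nc3-c3ccccc3)CC2)c1` is a close relative of compound 2: the two have the same atoms, joined differently. The change is 3,5-dimethylphenyl in place of 2,3-dimethylphenyl on an amine nitrogen in a ring. Going by the values given here, the only measured step at that ring nitrogen is the one from compound 1 to compound 2, a modest gain, but it swaps 3-cyanophenyl for 2,3-dimethylphenyl, whereas here one dimethylphenyl is exchanged for another. Among the compounds with values here, no measured step tells how the two dimethylphenyl groups compare, so the expectation rests on compound 2 alone. Compound 4 is therefore expected to show a step of a number 2.2 percentage points higher from compound 2 to compound 4 (within the scatter), which is within the scatter, with an estimated value of 32% and a range from 15% to 52%.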

Compound 4, percent of the compound remaining: 25.6%
Beside the measured number, compound 4's estimate is 6.4 percentage points above it; low and high end bracket the measured number.
By their numbers in this assay, from the lowest: compound 1; then compounds 4 and 2 (each within the scatter of the next); then compound 3.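

In this assay, exchanging 2,3-dimethylphenyl for 3,5-dimethylphenyl on the ring nitrogen gives a number 4.2 percentage points lower from compound 2 to compound 4 (within the scatter), so this assay cannot tell these two arrangements of the same two methyl groups apart. Replacing 3-cyanophenyl with 3,5-dimethylphenyl at that nitrogen gives a number 17.6 percentage points higher from compound 1 to compound 4 (beyond the scatter), which shows that the gain first seen with 2,3-dimethylphenyl is not limited to that one dimethylphenyl group, although the size of each gain is modest. No supporting information explains why both dimethylphenyl compounds give higher numbers than the 3-cyanophenyl compound.

The compounds shown leave open whether both methyl groups are needed, since a phenyl ring bearing a single methyl group would be required to separate their contributions. From the compounds shown here alone, it also remains open whether a methoxy group on the phenyl ring, or a cyclohexyl ring in place of the phenyl ring, would give a number close to those of the two dimethylphenyl compounds or one closer to that of the 3-cyanophenyl compound.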